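A few compounds are considered here, and "the series" means these few. Any claim that something is new, unique, unknown or untested is made for them only; others in the source may bear on it.

Working notes on the series. In a functional assay (Platelet, plasma) for inhibition, with Homo sapiens as the target (a higher number here means a weaker inhibitor, a lower number a stronger inhibitor), compound 3 `N#Cc1cc2c(nc1N1CCC(C(=O)NS(=O)(=O)Cc3cc(Cl)cc(Cl)c3)CC1)COC2=O` gives 30500 nM and compound 1 `N#Cc1cc2c(nc1N1CCC(F)(C(=O)NS(=O)(=O)Cc3ccc(Cl)cc3)CC1)COC2=O` gives 37200 nM, two values within the scatter of each other. Compound 2 `N#Cc1cc2c(nc1N1CCC(C(=O)NS(=O)(=O)Cc3ccccc3)CC1)CCC(Cl)C2=O` is reported only as a limit, > 300000 nM. Compound 4 `N#Cc1cc2c(nc1N1CCC(C(=O)NS(=O)(=O)c3ccc(Cl)s3)CC1)COC2=O` carries 5-chlorothiophen-2-yl in place of 3,5-dichlorobenzyl on a sulfonyl sulfur. Among the compounds with values here, no measured pair isolates this change, so the expectation in this assay is no step beyond the scatter, with neither direction favoured, and it starts from the 30500 nM of compound 3. The expected step is a 1.2-fold lower number from compound 3 to compound 4 (0.09 log units; within the scatter). For compound 4 the estimated value is 25000 nM, with an expected range of 7000 nM to 90000 nM.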

Compound 4, half-maximal inhibitory concentration: 4470 nM
Estimate against measurement, compound 4: 5.6-fold (0.75 log units) above, and the stated range ends above it.
By their numbers in this assay, from the lowest: compound 4; then compounds 3 and 1 (each within the scatter of the next). At a limit, above all of these: compound 2.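

The group on the sulfonyl sulfur can move the number in this assay beyond the scatter: there is a 6.8-fold lower number from compound 3 to compound 4 (0.83 log units; beyond the scatter) with 5-chlorothiophen-2-yl in place of 3,5-dichlorobenzyl. Within the data shown here, this is the only step that can be read, and the entering group is the smaller by heavy atoms. Nothing measured in the series bears on the reason for this step.

The compounds shown leave open whether the step follows the five-membered aromatic ring or its chlorine. An unsubstituted thiophen-2-yl or a 4-chlorophenyl on the same sulfur would separate the two.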